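A few compounds are considered here, and "the series" means these few. Any claim that something is new, unique, unknown or untested is made for them only; others in the source may bear on it.

Working notes on the series. Three analogues sharing one core have been measured in an assay on isolated protein with Bile acid receptor (Homo sapiens) as the target; on this read-out higher numbers stand for an effect only at larger amounts of compound and lower numbers for an effect already at smaller amounts. Compound 1 `COC(=O)/C=C/c1cccc(N(Cc2ccc(/C=C/c3c(F)cccc3F)cc2)C(=O)C(C)C)c1` gives 108 nM; compound 2 `COC(=O)/C=C/c1cccc(N(Cc2ccc(/C=C/c3ccc(F)cc3)cc2)C(=O)C(C)C)c1` gives 120 nM; compound 3 `COC(=O)/C=C/c1cccc(N(Cc2ccc(/C=C/c3ccccc3)cc2)C(=O)C(C)C)c1` gives 65 nM. Among the compounds with values here, the steps from compound 1 to compound 2 a 1.1-fold higher number from compound 1 to compound 2 (0.05 log units; within the scatter), from compound 1 to compound 3 a 1.7-fold lower number from compound 1 to compound 3 (0.22 log units; within the scatter) and from compound 2 to compound 3 a 1.8-fold lower number from compound 2 to compound 3 (0.27 log units; within the scatter) all fall within the scatter, so the three compounds are not separated on this assay, and compound 3 is simply the one with the lowest number recorded.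

Compound 4 `COC(=O)/C=C/c1cccc(N(Cc2ccc(-c3ccc(F)c(Cl)c3)cc2)C(=O)C(C)C)c1` has not been measured. Relative to compound 3 the change is 3-chloro-4-fluorophenyl in place of 2-phenylethenyl on an aromatic carbon: the 2-phenylethenyl group, with its one double bond outside aromatic rings, leaves, and a 3-chloro-4-fluorophenyl group enters directly on the aromatic carbon, para to a large group.

The measured steps only vary substituents on the distal ring while keeping the double-bonded linker; none of them removes that linker or shortens the chain. They therefore show that ring substitution alone changes little, but give no direct guide to losing the ethenyl unit. A moderate step is expected, most likely toward a higher number, as a 2.5-fold higher number from compound 3 to compound 4 (0.39 log units; beyond the scatter). Compound 4 is estimated at 160 nM, with a range from 50 nM to 550 nM.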

Compound 4, half-maximal effective concentration: 129 nM
Compound 4: the middle estimate sits 1.2-fold (0.09 log units) above what was measured; the range from low to high includes it.
By their numbers in this assay, from the lowest: compounds 3, 1, 2 and 4 (each within the scatter of the next).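

In this assay the 2-phenylethenyl group and its fluorinated forms can give way to a 3-chloro-4-fluorophenyl group entering directly on the aromatic carbon, and the series stays unseparated, with a 2.0-fold higher number from compound 3 to compound 4 (0.30 log units; within the scatter) and a 1.1-fold higher number from compound 2 to compound 4 (0.03 log units; within the scatter) and a 1.2-fold higher number from compound 1 to compound 4 (0.08 log units; within the scatter) as the steps. Within the data shown here, the earlier compounds varied only the fluoro substitution with the double bond outside aromatic rings kept in place, so this is the first indication that this position, para to a large group, accepts the loss of that double bond without a step beyond the scatter. No measurement at hand bears on why the two kinds of group read alike.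

Still open, from the compounds shown here alone, is how a plain phenyl group on that same aromatic carbon would read, which would help separate the effect of direct attachment from that of the chloro and fluoro substituents. Also open, going by these compounds, is whether a carboxylic acid in place of the methyl ester, or an amine on the incoming phenyl ring, would give a step beyond the scatter at all.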